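A few compounds are considered here, and "the series" means these few. Any claim that something is new, unique, unknown or untested is made for them only; others in the source may bear on it.

Measured compounds:
- compound 1 `COc1nc(N)nc2c1c(-c1cc3ccccc3o1)cn2[C@@H]1O[C@H](CO)[C@@H](O)[C@H]1O`: in an ADME assay on MRC5 cells (Homo sapiens), read by MTT assay, with a stated time of 72 h (a higher number here means a weaker inhibitor, a lower number a stronger inhibitor), compound 1 gives 22700 nM
- compound 2 `COc1ncnc2c1c(I)cn2[C@@H]1O[C@H](CO)[C@@H](O)[C@H]1O`: in this assay compound 2 gives 63000 nM
- compound 3 `O=c1[nH]cnc2c1c(-c1ccsc1)cn2[C@@H]1O[C@H](CO)[C@@H](O)[C@H]1O`: in this assay compound 3 gives > 100000 nM, which is a limit of the assay and not a number (the limit of > 100000 nM in this assay, at which 1 of the 3 values shown sits)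

Compound 2 holds the highest of the two numbers in this assay; its nearest neighbour is compound 1, whose number is lower by a gap beyond the scatter. Compound 3 contributes only a limit.

Compound 4 `COc1ncnc2c1c(-c1ccsc1)cn2[C@@H]1O[C@H](CO)[C@@H](O)[C@H]1O` is not yet measured. It differs from compound 2 as follows: thiophen-3-yl in place of iodo on an aromatic carbon. Among the measured compounds shown here, no pair among the measured compounds differs in a single place, so no measured step carries over directly. The two measured compounds that carry an aromatic ring rather than iodo do not give a lower number than compound 2 in any case that is beyond the scatter, and one of them reaches only the limit. The step from compound 2 to compound 4 is therefore expected to be small, within the scatter or towards a weaker inhibitor: a 1.2-fold higher number from compound 2 to compound 4 (0.08 log units; within the scatter) is the expected move. For compound 4 in this assay the estimate is 75000 nM, with a range from 25000 nM to 220000 nM, and a real chance that only a limit is reported.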

Compound 4, half-maximal inhibitory concentration: 75300 nM
Beside the measured number, compound 4's estimate is 1.0-fold (0.00 log units) below it; low and high end bracket the measured number.
By their numbers in this assay, from the lowest: compound 1; then compounds 2 and 4 (each within the scatter of the next). At a limit, above all of these: compound 3.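

In this assay, among the compounds shown here, the change from iodo to thiophen-3-yl on this aromatic carbon gives the first single-place step: a 1.2-fold higher number from compound 2 to compound 4 (0.08 log units; within the scatter). The step does not separate iodo from the larger aromatic ring at this position, and with thiophen-3-yl in place compound 4 gives 75300 nM, a number and not a limit. Compound 3, which carries the same thiophen-3-yl on a different core, gives a limit of the assay and not a number: the limit of > 100000 nM in this assay, at which 1 of the 4 values shown sits.

From the compounds shown here alone, it stays open whether an amine, a carboxylic acid or a longer chain at this position would move the number beyond the scatter. Going by these compounds, it also stays open whether the same change would give a step of similar size on the core of compound 1.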